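Amide variation on a shared triazolylthio-naphthol core

A few compounds are considered here, and "the series" means these few. Any claim that something is new, unique, unknown or untested is made for them only; others in the source may bear on it.

Measured so far in a functional assay on HCT-116 cells (Homo sapiens) for antiproliferative activity, read by MTT assay, with a stated time of 48 h; a lower number here means a stronger inhibitor, a higher number a weaker inhibitor:
compound 1 `O=C(Nc1cc(Sc2ncn[nH]2)c(O)c2ccccc12)c1cccc([N+](=O)[O-])c1` — 70200 nM
compound 2 `O=C(Nc1cc(Sc2ncn[nH]2)c(O)c2ccccc12)c1cccc(Cl)c1` — > 100000 nM

Compound 2 is known only as a limit of this assay, (the limit of > 100000 nM in this assay, at which 1 of the 2 values shown sits). Within the data shown here, the one measured step, an at least 1.4-fold higher number from compound 1 to compound 2 (0.15 log units; that floor lies within the scatter), has a floor within the scatter.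

Compound 3 `O=C(/C=C/c1ccccc1)Nc1cc(Sc2ncn[nH]2)c(O)c2ccccc12` is not yet measured; the change is 2-phenylethenyl in place of 3-chlorophenyl on a carbonyl carbon. Among the measured compounds shown here, no measured step covers an aryl-to-alkenyl exchange, so the only guide is that compound 1 and compound 2 both sit near or at the limit. For compound 3 the expected step is an at least 1.1-fold lower number from compound 2 to compound 3 (0.04 log units; that floor lies within the scatter). Compound 3 is estimated at 90000 nM, within 20000 nM to 300000 nM, with a fair chance of another limit.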

Compound 3, half-maximal inhibitory concentration: > 100000 nM
Compound 3: a limit, no number; the forecaster's own chance of this, stated with the estimate: 55%; at least 1.1-fold (0.04 log units) between middle value and limit.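

In this assay compound 3 gives > 100000 nM as a limit of the assay, not a number. On the carbonyl carbon, 2-phenylethenyl, with its double bond outside the aromatic ring, thus joins 3-chlorophenyl at this limit: the limit of > 100000 nM in this assay, at which 2 of the 3 values shown sit. Among these compounds, the only readable step is an at least 1.4-fold higher number from compound 1 to compound 3 (0.15 log units; that floor lies within the scatter) and the step between the two limits cannot be read.

On these data alone, whether an amine, a carboxylic acid or a longer chain on the carbonyl carbon gives a number rather than a limit stays open. So does the effect of any change on the shared core.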